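This account rests on a few compounds, and the source may have more. Where it says the series, first, only, none or still open, it means among the compounds named here.

In a functional assay on U-937 cells (Homo sapiens) for cytotoxicity, read by MTT assay, with a stated time of 3 days (a lower number here means a stronger inhibitor, a higher number a weaker inhibitor), compound 3 `N#Cc1c(NNC(N)=S)nc(SCc2nc3ccccc3[nH]2)nc1-c1ccccc1` gives 3 nM. Compound 1 `N#Cc1c(NN)nc(SCc2nc3ccccc3[nH]2)nc1-c1ccccc1` gives 3.9 nM and compound 2 `N#Cc1c(Nc2ccccc2)nc(SCc2nc3ccccc3[nH]2)nc1-c1ccccc1` gives 3.28 nM. These three values lie within the scatter of one another, so compound 3 stands level with the other two.

Compound 4 `CN1CCN(c2nc(SCc3nc4ccccc4[nH]3)nc(-c3ccccc3)c2C#N)CC1` keeps the shared core but changes one group: a group of 7 heavy atoms (5 carbon, 2 nitrogen; one six-membered non-aromatic ring with 2 hetero atoms) in place of a group of 5 heavy atoms (1 carbon, 3 nitrogen, 1 sulfur; no ring), on an aromatic carbon. A 4-methylpiperazin-1-yl group enters on an aromatic carbon, ortho to a cyano group, in place of a group of 5 heavy atoms with no ring.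

The three measured compounds differ from one another at this same carbon, so their steps are the closest guide. These are a 1.2-fold lower number from compound 1 to compound 2 (0.08 log units; within the scatter), a 1.3-fold lower number from compound 1 to compound 3 (0.11 log units; within the scatter) and a 1.1-fold lower number from compound 2 to compound 3 (0.04 log units; within the scatter), and each one stays within the scatter. Within the data shown here, the guide is indirect, as no measured compound carries a non-aromatic ring there. Even so, swapping this group has not moved the number so far, including the exchange that brought in a phenyl ring.

No shift beyond the scatter is therefore expected in this assay, and the expected step is a 1.2-fold higher number from compound 3 to compound 4 (0.08 log units; within the scatter). For compound 4 the estimate is 3.6 nM, with an expected range from 1.6 nM to 9 nM.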

Compound 4, half-maximal inhibitory concentration: 6.75 nM
The estimate for compound 4 lay 1.9-fold (0.27 log units) below the measured number, within the range that was stated.
By their numbers in this assay, from the lowest: compounds 3, 2, 1 and 4 (each within the scatter of the next, the first and the last beyond it).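

In this assay, among these compounds, changes at this carbon had so far produced no step beyond the scatter, and the 4-methylpiperazin-1-yl group gives the first ones: a 2.3-fold higher number from compound 3 to compound 4 (0.35 log units; beyond the scatter) and a 2.1-fold higher number from compound 2 to compound 4 (0.31 log units; beyond the scatter), both modest, while a 1.7-fold higher number from compound 1 to compound 4 (0.24 log units; within the scatter) stays inside it. Among the compounds shown here, the position therefore does respond to the group placed on it, though only slightly, and the one group here with a non-aromatic ring stands level with the hydrazine-type group of compound 1 alone. No measurement at hand bears on why the number moved.

With a single ring of this kind, the part played by the ring cannot be separated from that of its second nitrogen or its methyl group. A piperidine, a morpholine or an unsubstituted piperazine on this carbon would separate them.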